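The source may hold more compounds than are shown below. What is called first, only, known or untested is meant among the compounds shown, and "the series" means these compounds.

Compound 1 `O=C(C1CCCO1)N1CCc2nc(C#Cc3ccccc3)sc2C1` and compound 2 `O=C(C1CCC(F)(F)CC1)N1CCc2nc(C#Cc3ccccc3)sc2C1` are the measured pair. In an assay on HEK293 cells for negative allosteric modulation of metabotropic glutamate receptor 5 (Homo sapiens), read by FLIPR, with a stated time of 1 h (on this read-out higher numbers stand for weaker inhibition and lower numbers for stronger inhibition), compound 1 gives only a limit of the assay, > 10000 nM. Compound 2 likewise gives only a limit of the assay, > 10000 nM. The step that the two limits leave unreadable from compound 1 to compound 2 is therefore not readable in size, and compound 2 stands at the limit shared by both values (the limit of > 10000 nM in this assay, at which 2 of the 2 values shown sit). Compound 3 `CC1CCC(C(=O)N2CCc3nc(C#Cc4ccccc4)sc3C2)CC1` differs from compound 2 by 4-methylcyclohexyl in place of 4,4-difluorocyclohexyl on a carbonyl carbon. Within the data shown here, the single measured step bears on this change in the same part of the molecule but gives no readable size, so no step beyond the scatter is expected. The estimate for compound 3 is 15000 nM, within 5000 nM to 50000 nM. This expected outcome corresponds to a step that the limit leaves unreadable from compound 2 to compound 3.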

Compound 3, half-maximal inhibitory concentration: > 10000 nM
Compound 3: only a limit was reported; the forecaster's own chance of this, stated with the estimate: 80%; the middle value is on the limit's open side.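

Compound 3 also gives only a limit, so its steps from compound 1 and from compound 2 cannot be read in size: the limit of > 10000 nM in this assay, at which 3 of the 3 values shown sit.

The compounds shown leave open which group on the carbonyl carbon, if any, would give a measurable value in this assay.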